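Swapping Phenyl for Vinyl Across Two Cores

This account rests on a few compounds, and the source may have more. Where it says the series, first, only, none or still open, it means among the compounds named here.

Compound 1 `CC(C(=O)NOCc1ccccc1)N1C(=O)S/C(=C\c2ccccc2)C1=O` and compound 2 `C=CCONC(=O)C(C)N1C(=O)S/C(=C\c2ccccc2)C1=O` share one core, while compound 3 `O=C(CN1C(=O)S/C(=C\c2ccc(C(F)(F)F)cc2)C1=O)NOCc1ccccc1` and the still unmeasured compound 4 `C=CCONC(=O)CN1C(=O)S/C(=C\c2ccc(C(F)(F)F)cc2)C1=O` share another; the difference between the two cores is not broken down here. In an ADME assay on RAW264.7 cells (Mus musculus) for cytotoxicity, read by neutral red uptake, with a stated time of 24 h (on this read-out higher numbers stand for lower toxicity in this test and lower numbers for higher toxicity in this test), compound 1 gives only a limit, > 128000 nM. In this assay compound 2 also gives only a limit, > 128000 nM. Compound 3 in this assay gives only a limit as well, > 128000 nM. The change from compound 1 to compound 2 is vinyl in place of phenyl on a saturated chain carbon bound to an oxygen, and it makes a step that the two limits leave unreadable from compound 1 to compound 2. The change from compound 3 to compound 4 is the same change, (vinyl in place of phenyl on a saturated chain carbon bound to an oxygen). Because every measured value sits at the limit of > 128000 nM in this assay, at which 3 of the 3 values shown sit, the step is expected to be a step that the limit leaves unreadable from compound 3 to compound 4. Compound 4 is estimated at about 150000 nM, somewhere from 60000 nM to 400000 nM.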

Compound 4, half-maximal cytotoxic concentration: > 128000 nM
Compound 4: no number, only a limit; the forecaster's own chance of this, stated with the estimate: 85%; the middle value does not contradict the limit.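

Compound 3 and compound 4 both give only limits, not numbers, so no step between them can be read: the limit of > 128000 nM in this assay, at which 4 of the 4 values shown sit.

As far as these compounds go, what stays open in this assay is whether vinyl in place of phenyl changes the toxicity at all, and by how much.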